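The source may report more compounds than this note shows. Statements on the series, on what has been measured and on what is new or still open speak of the compounds shown alone.

In a functional assay on HepG2 cells (Homo sapiens) for cytotoxicity, with a stated time of 72 h (on this read-out lower numbers stand for an effect already at smaller amounts and higher numbers for an effect only at larger amounts of compound), compound 1 `C=C[C@@](C)(/C=C/c1ccc(Nc2ccc(OC)cc2)cc1)CCC=C(C)C` returns > 52000 nM as a limit and not a number. Compound 2 `C=C[C@@](C)(/C=C/c1ccc(Nc2ccc(OC)c(F)c2)cc1)CCC=C(C)C` likewise returns > 52000 nM as a limit. Compound 3 `C=C[C@@](C)(/C=C/c1ccc(Nc2ccc(OC(F)(F)F)cc2)cc1)CCC=C(C)C` also returns > 52000 nM as a limit. That leaves the limit of > 52000 nM in this assay, at which 3 of the 3 values shown sit, as the whole record, so compound 1 has no number to start from.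

Compound 4 `C=C[C@@](C)(/C=C/c1ccc(-c2ccccc2)cc1)CCC=C(C)C` keeps the core of compound 1 and differs by phenyl in place of (4-methoxyphenyl)amino on an aromatic carbon in one place, with phenyl in place of (4-methoxyphenyl)amino on an aromatic carbon. Both a step that the two limits leave unreadable from compound 1 to compound 2 and a step that the two limits leave unreadable from compound 1 to compound 3 bear on this change only loosely: each keeps the group that leaves, and neither has a readable size. They offer no size or direction to carry over. What is expected in this assay is therefore no clear step, estimated as a step that the limit leaves unreadable from compound 1 to compound 4 with the reading likely to remain a limit. Compound 4 is expected at 55000 nM with an estimated range from 25000 nM to 120000 nM around that figure.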

Compound 4, half-maximal effective concentration: > 52000 nM
Compound 4 gave a limit, no number; the forecaster's own chance of this, stated with the estimate: 75%; the middle value lies beyond the limit too.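

Going by these compounds alone, compound 1 and compound 4 both return only a limit in this assay, so no step between them can be read: the limit of > 52000 nM in this assay, at which 4 of the 4 values shown sit. The compounds shown leave open whether phenyl in place of (4-methoxyphenyl)amino changes this read-out at all, and what number any of them would give.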